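Ribose-bearing analogue with a pyridinylmethyl sulfur substituent

A few compounds are considered here, and "the series" means these few. Any claim that something is new, unique, unknown or untested is made for them only; others in the source may bear on it.

Compound 1 `CCCC(C)n1cnc2c(SCc3ccccn3)nc(N)nc21` gives 41700 nM in an assay on isolated protein for binding affinity to Equilibrative nucleoside transporter 1 (Homo sapiens); on this read-out lower numbers stand for stronger inhibition and higher numbers for weaker inhibition. Compound 2 `CSc1nc(N)nc2c1ncn2[C@@H]1O[C@H](CO)[C@@H](O)[C@H]1O` gives 204000 nM in this assay.

Compound 2 shows the highest number of the two, and its gap to compound 1 is beyond the scatter. Compound 3 `Nc1nc(SCc2ccccn2)c2ncn([C@@H]3O[C@H](CO)[C@@H](O)[C@H]3O)c2n1` differs from compound 2 by pyridin-2-yl in place of hydrogen on a saturated chain carbon bound to a sulfur. Within the data shown here, no measured pair shows this change on its own, so no step is known for it. The step is expected to lower the number beyond the scatter, which is a 6.8-fold lower number from compound 2 to compound 3 (0.83 log units; beyond the scatter). For compound 3 the estimated value in this assay is 30000 nM, with a range from 8000 nM to 120000 nM.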

Compound 3, half-maximal inhibitory concentration: 34700 nM
The estimate for compound 3 lay 1.2-fold (0.06 log units) below the measured number; the range from low to high includes it.
By their numbers in this assay, from the lowest: compounds 3 and 1 (each within the scatter of the next); then compound 2.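

On the sugar-bearing compounds, pyridin-2-yl in place of hydrogen on a saturated chain carbon bound to a sulfur gives a 5.9-fold lower number from compound 2 to compound 3 (0.77 log units; beyond the scatter) in this assay and this modest step lies beyond the scatter. With the ((pyridin-2-yl)methyl)sulfanyl group present, 3,4-dihydroxy-5-(hydroxymethyl)oxolan-2-yl in place of 1-methylbutyl on an aromatic nitrogen gives a 1.2-fold lower number from compound 1 to compound 3 (0.08 log units; within the scatter) and so lies within the scatter, leaving these two groups indistinguishable here. No evidence on the cause of either step is at hand.

On these data alone, whether phenyl would serve in place of pyridin-2-yl remains open. So does the effect of a longer chain on the sulfur.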